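Aryl swap on the shared core of compound 1

The compounds below may be only part of what the source reports. "The series", "measured", "known", "first", "only" and "open" are said of these compounds alone.

Compound 1 `Cc1ccc(Nc2cc(NC(=O)Nc3c(Cl)cccc3Cl)ncn2)cc1F` stands highest of the two measured entries: in a functional assay on HCC827 cells (Homo sapiens) for inhibition, read by MTT assay, with a stated time of 48 h, tested at 10 uM (on this read-out higher numbers stand for more inhibition at the one concentration tested (going by the name of the read-out) and lower numbers for less inhibition), compound 1 gives 85.3%, while compound 2 `CCc1cccc(Nc2cc(NC(=O)Nc3cc(OC)cc(OC)c3)ncn2)c1` gives 52.6%, a gap beyond the usual scatter. Compound 3 `O=C(Nc1cc(Nc2ccc(F)c(Cl)c2)ncn1)Nc1c(Cl)cccc1Cl` differs from compound 1 in one place: 3-chloro-4-fluorophenyl in place of 3-fluoro-4-methylphenyl on a nitrogen on an aromatic ring. Within the data shown here, no single-change step between measured compounds is available, so the size of this change has no anchor. The expectation is a small step, downward if any, within the scatter. The expected step is a number 5.3 percentage points lower from compound 1 to compound 3 (within the scatter). The estimate for compound 3 in this assay is 80%, with a range from 60% to 95%.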

Compound 3, a percentage reported as inhibition, at one concentration (the size of the read-out at that concentration, not a potency): 53.7%
Compound 3: the middle estimate sits 26.3 percentage points above what was measured; measured number outside the range, below it.
By their numbers in this assay, from the lowest: compounds 2 and 3 (each within the scatter of the next); then compound 1.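

Within this assay the swap of 3-fluoro-4-methylphenyl for 3-chloro-4-fluorophenyl on a nitrogen on an aromatic ring gives a number 31.6 percentage points lower from compound 1 to compound 3 (beyond the scatter) with the rest of compound 1 unchanged, so this position is sensitive to the change. The leaving and entering groups match in heavy-atom count and in hydrogen-bond donors and acceptors, so those counts do not separate compound 1 from compound 3. Nothing at hand speaks to the reason for the step.

Which part of the substitution change carries the step remains open. Also open, going by these compounds, is how this position responds to a different kind of group on that nitrogen, such as a pyridine ring or a phenyl ring bearing a carboxylic acid.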